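Reversing the Linker Amide on a Shared Core

This account rests on a few compounds, and the source may have more. Where it says the series, first, only, none or still open, it means among the compounds named here.

Compound 1 `CN(C)C(=O)c1cc2cnc(Nc3ccc(C(=O)NCCCCCN=C=S)cc3)nc2n1C1CCCC1` was tested in a functional assay on NCI-H1299 cells (Homo sapiens) for inhibition, read by CCK-8 assay, with a stated time of 72 h, tested at 10 uM (a lower number here means a weaker effect, a higher number a stronger effect of the compound at the concentration tested), where compound 1 gives 76.5%. Among the measured compounds shown here, its only measured neighbour is compound 2 `CN(C)C(=O)c1cc2cnc(Nc3ccc(C(=O)NCCCCCN=C=S)cc3O)nc2n1C1CCCC1`, which in this assay gives 80.7%; the step between them is a number 4.2 percentage points higher from compound 1 to compound 2 (within the scatter). Compound 1 thus holds the lower of the two numbers shown, but the gap to compound 2 lies within the scatter, so the two are not distinguished.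

Compound 3 `CN(C)C(=O)c1cc2cnc(Nc3ccc(NC(=O)CCCCCCN=C=S)cc3)nc2n1C1CCCC1` has not yet been measured. It differs from compound 1 in one place: a group of 12 heavy atoms (8 carbon, 2 nitrogen, 1 oxygen, 1 sulfur; no ring) in place of a group of 11 heavy atoms (7 carbon, 2 nitrogen, 1 oxygen, 1 sulfur; no ring), on an aromatic carbon. The chain carrying the isothiocyanate now joins the ring through a nitrogen rather than through a carbonyl.

For the measured compounds named here, no measured step bears on this change; the one step known, from compound 1 to compound 2, concerns a hydroxy group and is itself within the scatter. The account therefore has nothing to point to a shift in either direction. Compound 3 is expected to show a step of a number 2.5 percentage points lower from compound 1 to compound 3 (within the scatter), not beyond the scatter. Compound 3 is estimated at 74%, within a range from 55% to 90%.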

Compound 3, a percentage reported as inhibition, at one concentration (the size of the read-out at that concentration, not a potency): 80.9%
Compound 3: the middle estimate sits 6.9 percentage points below what was measured, within the range that was stated.
By their numbers in this assay, from the lowest: compounds 1, 2 and 3 (each within the scatter of the next).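

In this assay, putting the group of 12 heavy atoms (8 carbon, 2 nitrogen, 1 oxygen, 1 sulfur; no ring) in place of the group of 11 heavy atoms (7 carbon, 2 nitrogen, 1 oxygen, 1 sulfur; no ring), on an aromatic carbon para to a large group, gives a number 4.4 percentage points higher from compound 1 to compound 3 (within the scatter). The earlier compounds shown here had tested only a hydroxy group on the ring, whereas this step shows that the chain carrying the isothiocyanate can join the ring through a nitrogen rather than through a carbonyl, and can differ in size, without a step beyond the scatter at the one concentration tested. Nothing available explains why the read-out holds across this change.

Open, as far as these compounds go, is how the turned amide and the change in chain size would each read alone, as compound 3 carries both at once, and a read-out at one concentration is not a potency. Also open, from the compounds shown here alone, is how a shorter chain, or an acrylamide or a simple amine in place of the isothiocyanate at the chain end, would read on this core.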